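A few compounds are considered here, and "the series" means these few. Any claim that something is new, unique, unknown or untested is made for them only; others in the source may bear on it.

Measured so far in a functional assay on SMMC-7721 cells (Homo sapiens) for antiproliferative activity, read by CCK-8 assay, with a stated time of 48 h; a lower number here means a stronger inhibitor, a higher number a weaker inhibitor:
- compound 1 `O=c1c2ccccc2[se]n1-c1nc(SCc2ccccc2)n[nH]1`: 32000 nM
- compound 2 `CC(C)CSc1n[nH]c(-n2[se]c3ccccc3c2=O)n1`: 35000 nM

Among the compounds with values here, of these two numbers compound 1 has the lower one, with compound 2 its only neighbour, yet the step of a 1.1-fold higher number from compound 1 to compound 2 (0.04 log units; within the scatter) sits within the scatter, so the two cannot be ranked. Compound 3 `CC(C)Sc1n[nH]c(-n2[se]c3ccccc3c2=O)n1` has not been measured. It differs from compound 1 in one place: isopropyl in place of benzyl on a sulfur. Within the data shown here, the single measured step that bears on this change is a 1.1-fold higher number from compound 1 to compound 2 (0.04 log units; within the scatter), where a ring-bearing group on the sulfur side chain was likewise exchanged for a small branched saturated one, and the number barely moved. On that basis the loss of the benzyl ring in favour of isopropyl is expected to bring no step beyond the scatter in this assay, in either direction. Compound 3 is therefore estimated at 35000 nM, within a range of 17000 nM to 70000 nM, which is an expected step of a 1.1-fold higher number from compound 1 to compound 3 (0.04 log units; within the scatter).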

Compound 3, half-maximal inhibitory concentration: 6010 nM
Beside the measured number, compound 3's estimate is 5.8-fold (0.77 log units) above it; the whole stated range lies above it.
By their numbers in this assay, from the lowest: compound 3; then compounds 1 and 2 (each within the scatter of the next).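

In this assay the group on the sulfur turns out to matter, which the earlier pair could not show: isopropyl in place of benzyl gives a 5.3-fold lower number from compound 1 to compound 3 (0.73 log units; beyond the scatter), and isopropyl in place of isobutyl gives a 5.8-fold lower number from compound 2 to compound 3 (0.77 log units; beyond the scatter). Losing the ring is not enough on its own to go with the lower number, since compound 2 also has no ring on its sulfur chain and stays within the scatter of compound 1; among these three groups, only isopropyl stands apart. No measurement shown here explains why isopropyl gives the lower number.

From the compounds shown here alone, it remains open whether a methyl, an ethyl or a cyclopentyl on the sulfur would hold or extend this gain, or whether it is particular to isopropyl. A longer chain ending in an amine is likewise untested among the compounds shown.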